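The source may hold more compounds than are shown below. What is called first, only, known or untested is meant among the compounds shown, and "the series" means these compounds.

Compound 1 (`CCCc1ccc(NC2=CC(=O)c3nc4n(c3C2=O)[C@H]2OC[C@@H](O)[C@H]2OC4)cc1`) was tested in a functional assay on ECa-109 cells for inhibition, with ECa-109 cell line (Homo sapiens) as the target, read by sulforhodamine B assay (a lower number here means a stronger inhibitor, a higher number a weaker inhibitor), and gives only a limit there, > 4000 nM. A related compound 2 (`COc1ccc(NC2=CC(=O)c3c(nc4n3[C@H]3OC[C@@H](O)[C@H]3OC4)C2=O)cc1`) in this assay gives 3410 nM. Both numbers sit at the weak end of what was measured, as the limit of > 4000 nM in this assay, at which 1 of the 2 values shown sits, shows. Compound 3 (`Cc1ccc(NC2=CC(=O)c3nc4n(c3C2=O)[C@H]2OC[C@@H](O)[C@H]2OC4)cc1C`) differs from compound 1 only by 3,4-dimethylphenyl in place of 4-propylphenyl on an amine nitrogen, the shared core staying untouched. With both measured compounds weak, the expected step that the limit leaves unreadable from compound 1 to compound 3 should stay within the usual scatter. Compound 3 is therefore estimated at 5000 nM in this assay, with a likely range from 2500 nM to 12000 nM.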

Compound 3, half-maximal inhibitory concentration: 2820 nM
Compound 3: the middle estimate sits 1.8-fold (0.25 log units) above what was measured; the range from low to high includes it.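

In this assay, compound 3 gives a true number, 2820 nM, so this amine nitrogen can carry 3,4-dimethylphenyl and still yield a reading rather than a limit. From the compounds shown here alone, the change from 4-propylphenyl gives an at least 1.4-fold lower number from compound 1 to compound 3 (0.15 log units; that floor lies within the scatter), so the true size of the step is unknown, and its floor does not separate the two compounds. Compound 1 remains a limit, not a number: the limit of > 4000 nM in this assay, at which 1 of the 3 values shown sits.

Still open, going by these compounds, is whether a different kind of group on this nitrogen, such as a carboxylic acid or a simple open-chain amine, would move the number beyond the scatter.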